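The source may report more compounds than this note shows. Statements on the series, on what has been measured and on what is new or still open speak of the compounds shown alone.

Measured so far: compound 1 `COc1ccc(N(C)c2nc(C)nc3ccccc23)cc1C(=O)NCC[Se]C#N`, compound 2 `C[Se]c1ccc(N(C)c2nc(C3CC3)nc3ccccc23)cc1` and compound 3 `C[Se]c1ccc(N(C)c2nc(C)nc3ccccc23)cc1C`.

In a functional assay on LoVo cells (Homo sapiens) for inhibition, read by MTT assay, with a stated time of 48 h (a lower number here means a stronger inhibitor, a higher number a weaker inhibitor), compound 1 gives 561 nM, the highest of the three numbers. Compound 2 gives 11 nM and compound 3 gives 9 nM, both far lower than the number for compound 1. Compound 4 `COc1ccc(N(C)c2nc(C)nc3ccccc23)cc1[Se]C#N` has not yet been measured. It differs from compound 1 in a single place: a group of 3 heavy atoms (1 carbon, 1 nitrogen, 1 selenium; no ring) in place of a group of 8 heavy atoms (4 carbon, 2 nitrogen, 1 oxygen, 1 selenium; no ring), on an aromatic carbon. No step between measured compounds is shown for this exchange, so its size is open. Compounds 2 and 3 both carry a selenium group directly on the aromatic ring and give the low numbers, so a sizeable drop in the number for compound 4 is expected, a 7.0-fold lower number from compound 1 to compound 4 (0.85 log units; beyond the scatter). Compound 4 is therefore estimated at 80 nM, in a range of 15 nM to 400 nM.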

Compound 4, half-maximal inhibitory concentration: 73 nM
Compound 4: middle estimate off by 1.1-fold (0.04 log units), on the high side; measured number inside the range.
By their numbers in this assay, from the lowest: compounds 3 and 2 (each within the scatter of the next); then compound 4; then compound 1.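

In this assay, the group of 3 heavy atoms, in place of the group of 8 heavy atoms on the aromatic carbon ortho to a methoxy group, gives a 7.7-fold lower number from compound 1 to compound 4 (0.89 log units; beyond the scatter). Among these compounds, this is the only direct reading at this position, and it shows that the number responds to this exchange while selenium and the nitrile remain present in both compounds. Nothing measured here explains the change.

The compounds shown leave open whether the nitrile is needed at this position. From the compounds shown here alone, how an amine, a carboxylic acid or a chain of intermediate length would read on this carbon also remains open.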